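Swapping the aryl group on the piperazine of compound 3

This account rests on a few compounds, and the source may have more. Where it says the series, first, only, none or still open, it means among the compounds named here.

Within the data shown here, in an assay on HEK293 cells for displacement of a labelled ligand from 5-hydroxytryptamine receptor 7 (Homo sapiens) (on this read-out higher numbers stand for weaker inhibition and lower numbers for stronger inhibition), compound 3 `O=C1c2ccccc2S(=O)(=O)N1CCCCCN1CCN(c2cccc(C(F)(F)F)c2)CC1` gives 35 nM, the lowest of the three numbers measured so far. Compound 1 `COc1ccccc1N1CCN(CCCCCN2C(=O)c3ccccc3S2(=O)=O)CC1` gives 125 nM and compound 2 `O=C1c2ccccc2S(=O)(=O)N1CCCCCN1CCN(c2ccccn2)CC1` gives 179 nM; the two steps of a 3.6-fold lower number from compound 1 to compound 3 (0.55 log units; beyond the scatter) and a 5.1-fold lower number from compound 2 to compound 3 (0.71 log units; beyond the scatter) both lie beyond the scatter. Compound 4 `O=C1c2ccccc2S(=O)(=O)N1CCCCCN1CCN(c2cccc(Cl)c2Cl)CC1` differs from compound 3 in one place: 2,3-dichlorophenyl in place of 3-(trifluoromethyl)phenyl on an amine nitrogen in a ring. Among the measured compounds shown here, those two steps show that changing the ring on this nitrogen shifts this assay only modestly, and no measured compound carries a dichlorophenyl ring at this place. Compound 4 is therefore expected to remain close to compound 3. The expected step is a 1.1-fold higher number from compound 3 to compound 4 (0.06 log units; within the scatter), which may well fall within the scatter. The estimate for compound 4 is 40 nM, within the range 15 nM to 120 nM.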

Compound 4, inhibition constant: 149 nM
Compound 4: middle estimate off by 3.7-fold (0.57 log units), on the low side; measured number above the stated range.
By their numbers in this assay, from the lowest: compound 3; then compounds 1, 4 and 2 (each within the scatter of the next).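

In this assay there is a 4.3-fold higher number from compound 3 to compound 4 (0.63 log units; beyond the scatter), so the 2,3-dichlorophenyl ring does not keep the low number seen with 3-(trifluoromethyl)phenyl, and compound 3 alone stands apart among these four. With a 1.2-fold lower number from compound 2 to compound 4 (0.08 log units; within the scatter) and a 1.2-fold higher number from compound 1 to compound 4 (0.08 log units; within the scatter), the 2,3-dichlorophenyl ring sits level with pyridin-2-yl and 2-methoxyphenyl. No available measurement explains this difference. As far as these compounds go, it remains open whether the low number of compound 3 depends on the trifluoromethyl group itself or on where it sits on the ring. A 3-chlorophenyl or 2-(trifluoromethyl)phenyl ring on this nitrogen would help separate the two.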